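A few compounds are considered here, and "the series" means these few. Any claim that something is new, unique, unknown or untested is made for them only; others in the source may bear on it.

Measured in a functional assay on HT-29 cells (Homo sapiens) for antiproliferative activity, read by MTT assay, with a stated time of 72 h; a lower number here means a stronger inhibitor, a higher number a weaker inhibitor:
- compound 1 `Cn1ncnc1-c1cc(Oc2ccc(NC(=O)Nc3cccc(C(F)(F)F)c3)cc2F)ccn1`: > 50000 nM (a limit of the assay)
- compound 2 `CN(C)CCn1cnnc1-c1cc(Oc2ccc(NC(=O)Nc3ccc(Cl)c(C(F)(F)F)c3)cc2F)ccn1`: 880 nM

Within the data shown here, compound 2 holds the only actual number so far, 880 nM. Compound 1 is reported only as a limit, > 50000 nM.

Compound 3 `CN(C)CCn1cnnc1-c1cc(Oc2ccc(NC(=O)Nc3ccc(F)c(F)c3)cc2F)ccn1` departs from compound 2 in one place: 3,4-difluorophenyl in place of 4-chloro-3-(trifluoromethyl)phenyl on an amide-type nitrogen. This puts 3,4-difluorophenyl in place of 4-chloro-3-(trifluoromethyl)phenyl on an amide-type nitrogen. Among the measured compounds shown here, no measured step sizes this exchange, so the expectation is anchored on compound 2 at 880 nM and remains loose. Weaker inhibition in this assay is expected, by a moderate step probably beyond the usual scatter. The expected change is a 3.4-fold higher number from compound 2 to compound 3 (0.53 log units; beyond the scatter). For compound 3 the estimate is 3000 nM, with an expected range of 800 nM to 15000 nM.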

Compound 3, half-maximal inhibitory concentration: 3620 nM
Estimate against measurement, compound 3: 1.2-fold (0.08 log units) below; the measured number falls inside the stated range.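

In this assay, among these compounds, exchanging 4-chloro-3-(trifluoromethyl)phenyl for 3,4-difluorophenyl on an amide-type nitrogen gives a 4.1-fold higher number from compound 2 to compound 3 (0.61 log units; beyond the scatter), the only sized step so far. The position therefore responds to the choice of aryl group, yet compound 3 still gives an actual number, 3620 nM, with fewer heavy atoms in the entering group than in the leaving one. Nothing shown gives a cause for this step.

The exchange alters both ring substituents at once, so the separate shares of the chlorine and the trifluoromethyl remain unresolved. Among the compounds shown here, a phenyl carrying only one of these groups would separate them, and a methoxy or nitrile group on the same ring would show whether halogens are needed here at all.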